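From compound 1 to compound 4: hydroxy for methoxy

A few compounds are considered here, and "the series" means these few. Any claim that something is new, unique, unknown or untested is made for them only; others in the source may bear on it.

Measured so far:
compound 1 `COc1c(Br)cccc1C(=O)Nc1ccc(Sc2nc3ccccc3s2)c(Cl)c1`: > 100000 nM
compound 2 `COc1ccc(Br)cc1C(=O)Nc1ccc(Sc2nc3ccccc3s2)cc1`: > 100000 nM
compound 3 `COc1ccccc1C(=O)Nc1cccc(Cl)c1`: > 100000 nM

In an assay for inhibition of HSP60/HSP10 (Homo sapiens), with a stated time of 60 min (on this read-out lower numbers stand for stronger inhibition and higher numbers for weaker inhibition), compound 1 gives > 100000 nM, which is a limit of the assay and not a number. For the measured compounds named here, every value shown rests at the limit of > 100000 nM in this assay, at which 3 of the 3 values shown sit, so compound 1 stands nowhere above or below its neighbours; no step between measured compounds can be read off.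

Compound 4 `O=C(Nc1ccc(Sc2nc3ccccc3s2)c(Cl)c1)c1cc(Br)ccc1O` differs from compound 1 by a group of 8 heavy atoms (6 carbon, 1 oxygen, 1 bromine; one six-membered aromatic ring of carbon only) in place of a group of 9 heavy atoms (7 carbon, 1 oxygen, 1 bromine; one six-membered aromatic ring of carbon only), on a carbonyl carbon.

Going by the values given here, with no measured step to lean on, the expectation for this assay is a step of no size beyond the scatter, in no clear direction, since compound 1 gives only the limit > 100000 nM. Compound 4 is therefore expected at 70000 nM, within 10000 nM to 100000 nM, an estimated step of an at least 1.4-fold lower number from compound 1 to compound 4 (0.15 log units; that floor lies within the scatter).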

Compound 4, half-maximal inhibitory concentration: > 100000 nM
Compound 4 was reported as a limit (the forecaster's own chance of this, stated with the estimate: 65%); at least 1.4-fold (0.15 log units) between middle value and limit.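

In this assay compound 4 gives > 100000 nM, a limit of the assay; compound 1 also rests at a limit, so no step between them can be read: the limit of > 100000 nM in this assay, at which 4 of the 4 values shown sit.

The compounds shown leave open whether the 5-bromo-2-hydroxyphenyl group changes inhibition at all, as none of them yields a value that is a number.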